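Series notes: chloro on the benzoyl ring, compound 4

This account rests on a few compounds, and the source may have more. Where it says the series, first, only, none or still open, it means among the compounds named here.

Compound 3 `Cc1nnc(CN2CCCC2)n1-c1ccc(Cl)cc1C(=O)c1ccccc1` gives 4 mg/kg in a functional assay on the whole organism (strain CF-1) with Mus musculus as the target (on this read-out higher numbers stand for an effect only at larger amounts of compound and lower numbers for an effect already at smaller amounts), and sits with the lowest of the two numbers recorded so far. Compound 2 `Cc1nnc(CN(C)C)n1-c1ccc(Cl)cc1C(=O)c1ccccc1` gives 5 mg/kg in this assay, and the step of a 1.3-fold lower number from compound 2 to compound 3 (0.10 log units; within the scatter) leaves the two indistinguishable. Compound 1 `Cc1nnc(CN2CCCC2)n1-c1ccc(Cl)cc1Cc1ccccc1` reaches only a limit in this assay, > 100 mg/kg. The step of an at least 25-fold lower number from compound 1 to compound 3 (1.39 log units; beyond the scatter) is the one clear effect in the set, resting on (the limit of > 100 mg/kg in this assay, at which 1 of the 3 values shown sits).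

Compound 4 `Cc1nnc(CN2CCCC2)n1-c1ccc(Cl)cc1C(=O)c1ccccc1Cl` differs from compound 3 by chloro in place of hydrogen on an aromatic carbon, on an aromatic carbon of a six-membered aromatic ring of carbon only, ortho to a large group; read one bond further out, benzoyl becomes (2-chlorophenyl)carbonyl. Neither measured step touches this phenyl: one swaps the linker, the other the amine. The amine swap moved the number within the scatter; the linker swap is not comparable here. Among the measured compounds shown here, with no step on this ring, no change beyond the scatter is expected, so compound 4 is estimated at 4 mg/kg, between 1.5 mg/kg and 12 mg/kg, which is an expected step of no change at the digits printed from compound 3 to compound 4 (within the scatter).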

Compound 4, dose for half-maximal effect: 18 mg/kg
Estimate against measurement, compound 4: 4.5-fold (0.65 log units) below, outside the stated range (above it).
By their numbers in this assay, from the lowest: compounds 3 and 2 (each within the scatter of the next); then compound 4. At a limit, above all of these: compound 1.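

Among the compounds shown here, compound 4 gives the first reading on the phenyl of the benzoyl group, and this ring is not silent in this assay: the step of a 4.5-fold higher number from compound 3 to compound 4 (0.65 log units; beyond the scatter) shows that a single chloro, ortho to a large group, moves the number beyond the scatter, whereas the amine swap stayed within it. The direction is unfavourable, since a higher number here means that a larger amount of compound is needed for the effect. Even so, the 2-chlorophenyl ketone keeps a clear lead over the benzyl compound in the step of an at least 5.5-fold lower number from compound 1 to compound 4 (0.74 log units; beyond the scatter), which rests on a limit for compound 1: the limit of > 100 mg/kg in this assay, at which 1 of the 4 values shown sits.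

The compounds shown leave open whether fluoro or methoxy in place of this chloro would shift the number in the same direction. They also leave open whether the chloro step carries over to the dimethylamino compound 2.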